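The compounds below may be only part of what the source reports. "The series", "measured", "known", "first", "only" and "open" are said of these compounds alone.

Three compounds were measured in a functional assay on DU-145 cells (Homo sapiens) for cytotoxicity, read by CCK-8 assay and cell counting, with a stated time of 2 days; a lower number here means a stronger inhibitor, a higher number a weaker inhibitor:
compound 1 `Oc1ccc(-c2cc(-c3ccc(Cl)cc3)nc(-c3cccnc3)c2)cc1` gives 22800 nM;
compound 2 `Oc1cccc(-c2cc(-c3ccc(Cl)cc3)nc(-c3ccsc3)c2)c1` gives 11600 nM;
compound 3 `Oc1ccc(-c2cc(-c3cccnc3)nc(-c3cccc(Cl)c3)c2)cc1` gives 22900 nM.

Compound 1 and compound 3 share a core and differ in one place: 3-chlorophenyl in place of 4-chlorophenyl on an aromatic carbon. That change made a step of a 1.0-fold higher number from compound 1 to compound 3 (0.00 log units; within the scatter) in this assay, so the two numbers sit within the scatter of this kind of measurement. How the core of compound 2 differs from that of compound 1 is not broken down here; their two values lie within the scatter of each other.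

The unmeasured compound 4 `Oc1cccc(-c2cc(-c3ccsc3)nc(-c3cccc(Cl)c3)c2)c1` stands to compound 2 as compound 3 stands to compound 1: 3-chlorophenyl in place of 4-chlorophenyl on an aromatic carbon. The surroundings differ, though: in compound 2 the place is meta to a 3-hydroxyphenyl group and meta to a thiophen-3-yl group, whereas in compound 1 it is meta to a 4-hydroxyphenyl group and meta to a pyridin-3-yl group, so this is the same kind of change rather than the same change. Going by the values given here, the earlier step of a 1.0-fold higher number from compound 1 to compound 3 (0.00 log units; within the scatter) is the only guide available. A step of similar size is expected here, a 1.0-fold higher number from compound 2 to compound 4 (0.01 log units; within the scatter) in this assay. Compound 4 is therefore estimated at 12000 nM, most likely between 5000 nM and 30000 nM.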

Compound 4, half-maximal inhibitory concentration: 3330 nM
The estimate for compound 4 lay 3.6-fold (0.56 log units) above the measured number; the measured number lies below the stated range.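

In this assay, 3-chlorophenyl in place of 4-chlorophenyl gave a 3.5-fold lower number from compound 2 to compound 4 (0.54 log units; beyond the scatter), a modest step, so the swap that made no measurable difference on one core made a real one on the other. The effect of this change therefore did not carry over unchanged between the two cores: the same change on two cores in this assay, a 1.0-fold higher number (0.00 log units; within the scatter) from compound 1 to compound 3 and a 3.5-fold lower number (0.54 log units; beyond the scatter) from compound 2 to compound 4, 3.5-fold (0.54 log units) apart, beyond the scatter of two such steps. The two cores differ in both the hydroxyphenyl group (4-hydroxyphenyl against 3-hydroxyphenyl) and the other ring (pyridin-3-yl against thiophen-3-yl), and these two pairs do not show which of those differences matters, or how the swap would behave on any further core.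

A compound pairing 3-hydroxyphenyl with pyridin-3-yl, or 4-hydroxyphenyl with thiophen-3-yl, would help to separate those two differences. Also open, on these data alone, is what an amine or a carboxylic acid in place of the chlorine would do on the core of compound 4.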